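The compounds below may be only part of what the source reports. "The series", "measured", "known", "first", "only" and "open" are said of these compounds alone.

Of the compounds shown here, three have been measured in an assay on CHO cells for antagonist activity at transient receptor potential cation channel subfamily V member 1 (Homo sapiens), read by scintillation counting, with a stated time of 5 min, in the presence of a further agent that is not named here; a lower number here means that less compound is needed, a higher number that more compound is needed for the effect: compound 1 `CC(C(=O)NCc1ccc(C(F)(F)F)cc1N1CCC(Cc2ccccc2)(N(C)C)CC1)c1ccc(NS(C)(=O)=O)c(F)c1` gives 8.2 nM; compound 2 `CN(C)C1(Cc2ccccc2)CCN(c2cc(C(F)(F)F)ccc2CNC(=O)Nc2ccc(CNS(C)(=O)=O)c(F)c2)CC1` gives 25 nM; compound 3 `CN(C)C1(Cc2ccccc2)CCN(c2cc(C(F)(F)F)ccc2CNC(=O)Nc2ccc3c(c2)OCC3)CC1` gives 31.3 nM.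

Compound 3 has the highest number of the three. The number of compound 2 lies within the usual scatter of it, so the two cannot be ordered, while the number of compound 1 lies beyond the scatter, lower. Compound 4 `CN(C)C1(Cc2ccccc2)CCN(c2cc(C(F)(F)F)ccc2CNC(=O)Nc2cccc3ncccc23)CC1` differs from compound 3 in one place: a group of 10 heavy atoms (9 carbon, 1 nitrogen; one six-membered aromatic ring of carbon only, one six-membered aromatic ring with 1 hetero atom) in place of a group of 9 heavy atoms (8 carbon, 1 oxygen; one five-membered non-aromatic ring with 1 hetero atom, one six-membered aromatic ring of carbon only), on an amide-type nitrogen. Going by the values given here, no measured pair shows this change, so the expectation for compound 4 in this assay rests on compound 3 alone, and a step of modest size, not clearly beyond the scatter in either direction, is expected. Compound 4 is estimated at 30 nM, with a range from 10 nM to 100 nM. This corresponds to an expected step of a 1.0-fold lower number from compound 3 to compound 4 (0.02 log units; within the scatter).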

Compound 4, half-maximal effective concentration: 32 nM
Estimate against measurement, compound 4: 1.1-fold (0.03 log units) below, and the stated range covers the measured number.
By their numbers in this assay, from the lowest: compound 1; then compounds 2, 3 and 4 (each within the scatter of the next).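

In this assay, quinolin-5-yl on the amide-type nitrogen, in place of a group holding a five-membered non-aromatic ring with one oxygen, gives a 1.0-fold higher number from compound 3 to compound 4 (0.01 log units; within the scatter), so this position accepts either group with no measurable difference. The earlier compounds shown here, which differ from one another in more than one place, could not show this. Nothing on hand bears on why the two groups read alike. From the compounds shown here alone, it remains open whether a plain phenyl, or a quinolin-5-yl carrying a carboxylic acid, would read alike on this nitrogen.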